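A few compounds are considered here, and "the series" means these few. Any claim that something is new, unique, unknown or untested is made for them only; others in the source may bear on it.

Compound 1, with the structure `O=C(O)/C=N/OC(CC1CCCCC1)c1ccc(OCc2ccc3ccccc3n2)cc1`, and compound 2, with the structure `C/C(=N\OC(CC1CCCCC1)c1ccc(OCc2ccc3ccccc3n2)cc1)C(=O)O`, share one core, and compound 3, with the structure `O=C(O)/C=N/OC(c1ccc(OCc2nc(-c3ccccc3)cs2)cc1)C1CCCCC1`, carries a second one; compound 4, with the structure `C/C(=N\OC(c1ccc(OCc2nc(-c3ccccc3)cs2)cc1)C1CCCCC1)C(=O)O`, is the counterpart of compound 2 on that second core and has not yet been measured. The difference between the two cores is not broken down here. In a functional assay for inhibition of Polyunsaturated fatty acid 5-lipoxygenase (Homo sapiens) (on this read-out higher numbers stand for weaker inhibition and lower numbers for stronger inhibition), compound 1 gives 27 nM, and compound 2 gives 29 nM; the step of a 1.1-fold higher number from compound 1 to compound 2 (0.03 log units; within the scatter) belongs to the change (a group of 6 heavy atoms (3 carbon, 1 nitrogen, 2 oxygen; no ring) in place of a group of 5 heavy atoms (2 carbon, 1 nitrogen, 2 oxygen; no ring), on an oxygen on a saturated carbon). In this assay compound 3 gives 21 nM, and its values alongside those of compound 1 and compound 2 show no separation beyond the scatter. The change from compound 3 to compound 4 is the same change, (a group of 6 heavy atoms (3 carbon, 1 nitrogen, 2 oxygen; no ring) in place of a group of 5 heavy atoms (2 carbon, 1 nitrogen, 2 oxygen; no ring), on an oxygen on a saturated carbon), made once more, now on the core of compound 3. Within the data shown here, since the one measured instance of this change left the number essentially where it was, compound 4 is expected to sit close to compound 3, and the step of a 1.1-fold higher number from compound 3 to compound 4 (0.04 log units; within the scatter) is the estimated outcome, resting on compound 3 giving 21 nM and on the earlier step of a 1.1-fold higher number from compound 1 to compound 2 (0.03 log units; within the scatter). On that basis compound 4 is estimated at 23 nM in this assay, with a range from 11 nM to 48 nM that allows for the usual scatter.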

Compound 4, half-maximal inhibitory concentration: 20 nM
Estimate against measurement, compound 4: 1.2-fold (0.06 log units) above; measured number inside the range.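

In this assay, putting the group of 6 heavy atoms in place of the group of 5 heavy atoms on the core of compound 3 gives a 1.1-fold lower number from compound 3 to compound 4 (0.02 log units; within the scatter), so the two compounds cannot be told apart on this read-out. The same holds on the core of compound 1, and the two steps agree with each other: the same change on two cores in this assay, a 1.1-fold higher number (0.03 log units; within the scatter) from compound 1 to compound 2 and a 1.1-fold lower number (0.02 log units; within the scatter) from compound 3 to compound 4, 1.1-fold (0.05 log units) apart, within the scatter of two such steps This shows that, on these two cores, the change left the number within the scatter both times, but it rests on a single pair per core and does not show that the change would behave the same way on any other core or in any other assay.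

The compounds shown leave open whether a larger replacement, such as a longer chain in that same place, would still leave the number within the scatter, since only these two groups appear there. They also leave open what an amide or an ester in place of the carboxylic acid would do on either core, as every compound shown carries the carboxylic acid.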